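The source may hold more compounds than are shown below. What is called first, only, known or untested is meant among the compounds shown, and "the series" means these compounds.

Working notes on the series. Compound 1 `C=CC1=C(C(=O)NCCC)C(c2ccc(F)cc2)OC1` and compound 2 `C=CC1=C(C(=O)NCc2ccccc2)C(c2ccc(OC)c(OC)c2)OC1` share the same core, each carrying the vinyl group and the amide. In a functional assay on A549 cells (Homo sapiens) for cytotoxicity, read by MTT assay, with a stated time of 24 h (a higher number here means a weaker inhibitor, a lower number a stronger inhibitor), compound 1 gives > 100000 nM, which is a limit of the assay and not a number. In this assay compound 2 gives > 100000 nM, again a limit of the assay rather than a measured number. Compound 2 therefore stands exactly where every value in the set stands, namely (the limit of > 100000 nM in this assay, at which 2 of the 2 values shown sit). For the measured compounds named here, no step between measured compounds can be drawn, as compound 1 and compound 2 differ in more than one place and both values are limits.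

Compound 3 `C=CC1=C(C(=O)NCc2ccccc2)C(c2ccc(OC)cc2)OC1` differs from compound 2 in a single place: hydrogen in place of methoxy on an aromatic carbon. Going by the values given here, no measured pair shows what this change does in this assay, so the expectation is no step beyond the scatter, with a further limit the most likely outcome. Compound 3 is expected to give about 150000 nM in this assay, within a range of 50000 nM to 500000 nM. The step this estimate implies, a step that the limit leaves unreadable from compound 2 to compound 3, is expected to lie within the scatter.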

Compound 3, half-maximal inhibitory concentration: > 100000 nM
Compound 3 was reported as a limit (the forecaster's own chance of this, stated with the estimate: 80%); the middle value lies beyond the limit too.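

No step can be read from compound 2 to compound 3 in this assay, since both results are limits of the assay and not numbers: the limit of > 100000 nM in this assay, at which 3 of the 3 values shown sit.

The compounds shown leave open what hydrogen in place of methoxy on an aromatic carbon does in this assay, and whether any change to the shared core would give a readable value there.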